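Hydroxy for Methyl on a Double-Bonded Nitrogen

The source may hold more compounds than are shown below. What is called first, only, known or untested is meant among the compounds shown, and "the series" means these compounds.

In a functional assay on the whole organism with Rattus norvegicus as the target (a higher number here means that more compound is needed for the effect, a lower number that less compound is needed), compound 1 `CCCCn1c(=N)sc2cc(OC(F)(F)F)ccc21` stands at 10 mg/kg and compound 2 `N=c1sc2cc(OC(F)(F)F)ccc2n1CCN1CCC(c2ccccc2)CC1` at 3 mg/kg while compound 3 `CCSCCn1/c(=N/C)sc2cc(OC(F)(F)F)ccc21` gives 3.7 mg/kg on the same scale. Compound 3 is level with compound 2 within the scatter, and its number is lower than that of compound 1 by more than the scatter.

Compound 4 `CCSCCn1/c(=N/O)sc2cc(OC(F)(F)F)ccc21` differs from compound 3 in one place, with hydroxy in place of methyl on a double-bonded nitrogen. Among the compounds with values here, no measured pair shows this change alone, so the data offer no direct guide to it. The three measured compounds carry different groups yet lie no further apart than compound 2 at 3 mg/kg and compound 1 at 10 mg/kg on this scale, and only a small shift towards a higher number is therefore expected. The estimated step is a 1.4-fold higher number from compound 3 to compound 4 (0.13 log units; within the scatter) and it is expected to stay within the scatter. In this assay compound 4 is expected at 5 mg/kg within an estimated range of 2 mg/kg to 14 mg/kg for now.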

Compound 4, dose for half-maximal effect: > 10 mg/kg
Compound 4 was reported as a limit; the forecaster's own chance of this, stated with the estimate: 10%; middle value at least 2.0-fold (0.30 log units) away from the limit.
By their numbers in this assay, from the lowest: compounds 2 and 3 (each within the scatter of the next); then compound 1.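

With everything else held fixed, the exchange of methyl for hydroxy on the double-bonded nitrogen is the only single change among the compounds shown, and in this assay it gives an at least 2.7-fold higher number from compound 3 to compound 4 (0.43 log units; beyond the scatter). Compound 4 is known only through a limit, not a number: the limit of > 10 mg/kg in this assay, at which 1 of the 4 values shown sits. This shows that the group on this nitrogen is not a matter of indifference in this assay, something compounds 1, 2 and 3 could not show, as they differ from one another in more than one place.

From the compounds shown here alone, how far compound 4 really lies beyond its limit remains open, as does whether the shift belongs to the hydroxy group or to the loss of methyl. A methoxy, ethyl or acetyl group on the same nitrogen, with the rest of compound 3 unchanged, would bear on that question.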